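Cytotoxicity limits across a benzyl substituent change

The source may hold more compounds than are shown below. What is called first, only, known or untested is meant among the compounds shown, and "the series" means these compounds.

Measured so far in an ADME assay on MT4 cells (Homo sapiens) for cytotoxicity, read by MTT assay, with a stated time of 4 days; a lower number here means that less compound is tolerated, a higher number that more compound is tolerated:
compound 1 `CCOC(=O)c1cnc(N2CCN(Cc3ccc(F)cc3)CC2)nc1Oc1c(C)cc(-c2ccc(C#N)cc2)cc1C`: > 117000 nM
compound 2 `CCOC(=O)c1cnc(N2CCN(Cc3cccc(F)c3)CC2)nc1Oc1c(C)cc(-c2ccc(C#N)cc2)cc1C`: > 125000 nM

Both values are limits of this assay, not numbers. Compound 1 tolerates at least the highest concentration tested, so its value is a limit. Compound 2 likewise sits at a limit in this assay. Because of the limit of > 117000 nM in this assay, at which 1 of the 2 values shown sits, and the limit of > 125000 nM in this assay, at which 1 of the 2 values shown sits, the step that the two limits leave unreadable from compound 1 to compound 2 cannot be read in either direction or size; all that is known is that neither compound shows measurable cytotoxicity in the tested range.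

Compound 3 `CCOC(=O)c1cnc(N2CCN(Cc3cccc(C(=O)OC)c3)CC2)nc1Oc1c(C)cc(-c2ccc(C#N)cc2)cc1C` differs from compound 2 by methoxycarbonyl in place of fluoro on an aromatic carbon. Among the compounds with values here, no measured step bears on this change; the only measured step is itself unreadable. The expected step of an at least 1.0-fold lower number from compound 2 to compound 3 (0.01 log units; that floor lies within the scatter) is therefore none beyond the scatter, carried only by the two limits. Compound 3 is expected at 120000 nM, between 30000 nM and 300000 nM, most likely reported again as a limit.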

Compound 3, half-maximal cytotoxic concentration: > 125000 nM
Compound 3: no number, only a limit; the forecaster's own chance of this, stated with the estimate: 75%; middle value at least 1.0-fold (0.01 log units) from the limit.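

In this assay compound 3 gives > 125000 nM, which is a limit and not a number. Within the data shown here, no step among compound 1, compound 2 and compound 3 can be read. The compounds shown leave open at what concentration, if any, each becomes cytotoxic, and whether either substituent change alters this.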